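The source may hold more compounds than are shown below. What is called first, only, known or untested is meant among the compounds shown, and "the series" means these compounds.

Compound 2 `Nc1c2c(=O)[nH]c(-c3ccccn3)cc2nn1-c1ccccc1` is one of two measured members of a small series built on a shared core, the other being compound 1 `Cc1cc2nn(-c3ccccc3)c(N)c2c(=O)[nH]1`. In an assay on isolated protein for inhibition of ribosomal protein S6 kinase alpha-5 (Homo sapiens), read by mobility shift assay, tested at 30 uM (on this read-out higher numbers stand for more inhibition at the one concentration tested (going by the name of the read-out) and lower numbers for less inhibition), compound 1 gives 4%, and in this assay compound 2 gives 4%. The step of no change at the digits printed from compound 1 to compound 2 (within the scatter) shows that exchanging the group on that aromatic carbon left the read-out where it was, within the scatter, so compound 2 stands level with compound 1 and both sit near the bottom of the scale.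

The next compound, compound 3 `COc1ccccc1-c1cc2nn(-c3ccccc3)c(N)c2c(=O)[nH]1`, differs from compound 2 in the same position: 2-methoxyphenyl in place of pyridin-2-yl on an aromatic carbon. Going by the values given here, the only measured step that bears on this change is the one from compound 1 to compound 2, and that step was flat within the scatter. With a single flat precedent and no other data on this position, the expectation for compound 3 is no step beyond the scatter in this assay, a change of about a number 1 percentage points higher from compound 2 to compound 3 (within the scatter). Compound 3 is therefore estimated to give 5% in this assay, within a range of 0% to 18%.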

Compound 3, a percentage reported as inhibition, at one concentration (the size of the read-out at that concentration, not a potency): 7%
Estimate against measurement, compound 3: 2 percentage points below; the measured number falls inside the stated range.
By their numbers in this assay, from the lowest: compounds 1, 2 and 3 (each within the scatter of the next).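

In this assay, 2-methoxyphenyl in place of pyridin-2-yl gives a number 3 percentage points higher from compound 2 to compound 3 (within the scatter), and 2-methoxyphenyl in place of methyl gives a number 3 percentage points higher from compound 1 to compound 3 (within the scatter). The earlier pair compared only methyl and pyridin-2-yl, whereas this position, on the aromatic carbon next to the ring nitrogen, has now carried three different groups, including a six-membered aromatic ring of carbon only with a methoxy group on it, and neither new step leaves the scatter. Nothing among the data given accounts for this flat read-out, and none of it speaks to how these groups act at this position.

The three compounds leave open whether any group on this carbon can move the read-out beyond the scatter, for instance an amine, a carboxylic acid or a longer alkyl chain in place of 2-methoxyphenyl. They also leave open what a change at any other place on the shared core would do, since all three compounds differ only at this one carbon.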